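This account rests on a few compounds, and the source may have more. Where it says the series, first, only, none or still open, it means among the compounds named here.

Of the compounds shown here, two that share one core have been tested for how well they displace a labelled ligand from the human adenosine A3 receptor. Compound 1 `CC(=O)c1cc(C(=O)c2ccccc2)c(=O)[nH]c1C` gives 0% in an assay on CHO cells for displacement of a labelled ligand from adenosine receptor A3 (Homo sapiens), tested at 10 uM; on this read-out higher numbers stand for more inhibition at the one concentration tested (going by the name of the read-out) and lower numbers for less inhibition. Compound 2 `O=C1CCCc2[nH]c(=O)c(C(=O)c3ccccc3)cc21` gives 0% in this assay, which is level with compound 1: the two numbers lie within the usual scatter of repeated measurements, so neither can be called stronger or weaker than the other.

Compound 3 `O=C1CC(c2ccccc2)Cc2[nH]c(=O)c(C(=O)c3ccccc3)cc21` has not yet been measured. It differs from compound 2 in one place (phenyl in place of hydrogen on a saturated ring carbon), the new phenyl sitting on a saturated ring carbon of the six-membered non-aromatic ring of carbon only that forms part of the fused two-ring system. Among the measured compounds shown here, no step between two measured compounds is available to guide the expectation. The step from compound 2 to compound 3 is expected to be a number 5 percentage points higher from compound 2 to compound 3 (within the scatter), which is no change beyond the scatter. Compound 3 is therefore estimated to give 5% in this assay, with a range from -5% to 30%.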

Compound 3, a percentage reported as inhibition, at one concentration (the size of the read-out at that concentration, not a potency): 0%
The estimate for compound 3 lay 5 percentage points above the measured number; the range from low to high includes it.
By their numbers in this assay, from the lowest: compounds 1, 2 and 3 (each within the scatter of the next).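

In this assay phenyl in place of hydrogen on a saturated ring carbon gives no change at the digits printed from compound 2 to compound 3 (within the scatter) in a six-membered non-aromatic ring of carbon only. Among the compounds shown here, this is the first look at this position, and placing a whole aromatic ring there does not lift the number out of the scatter around compound 2, so the three compounds still cannot be ranked. No measurement is available that would explain this result.

Going by these compounds, whether a different group on this saturated ring carbon, such as an amine, a carboxylic acid or a longer chain, would move the number remains open. Also open, on these data alone, is whether a change elsewhere on the shared core would bring any measurable inhibition at all.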